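The source may report more compounds than this note shows. Statements on the series, on what has been measured and on what is new or still open speak of the compounds shown alone.

Measured so far in an ADME assay on cells (Macrophage) for cytotoxicity, read by resazurin assay, with a stated time of 48 h; a lower number here means that less compound is tolerated, a higher number that more compound is tolerated
Compound 1 `O=C(/C=C/c1c(F)cccc1Cl)c1ccc(OCc2cn(Cc3ccc(Br)cc3)nn2)cc1O` gives 65800 nM
Compound 2 `Nc1nc(-c2ccc(Cl)cc2)cc(-c2ccc(OCc3cn(Cc4ccccc4)nn3)cc2O)n1` gives 66600 nM
Compound 3 `CCCCCCn1cc(COc2ccc(-c3cc(-c4cccc5ccccc45)nc(N)n3)c(O)c2)nn1` reads "not determined" (no result reported)

Only two of these compounds carry a number, so there is little to set compound 2 against. Compound 2 at 66600 nM and compound 1 at 65800 nM lie within the usual scatter of each other and cannot be told apart. Compound 3 adds no number to the comparison.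

Compound 4 `COc1ccc(-c2cc(-c3ccc(OCc4cn(Cc5ccccc5)nn4)cc3O)nc(N)n2)cc1` has yet to be measured. It differs from compound 2 by one swap, methoxy in place of chloro on an aromatic carbon with methoxy in place of chloro on an aromatic carbon of a six-membered aromatic ring of carbon only, para to a large group. Put simply, a 4-chlorophenyl becomes a 4-methoxyphenyl.

Within the data shown here, no pair of measured compounds shows this change, so the data offer no direct guide to its size. The expectation therefore starts from compound 2 at 66600 nM in this assay and assumes no firm direction. The expected move is a 1.1-fold lower number from compound 2 to compound 4 (0.05 log units; within the scatter) and is not expected to exceed the scatter. Compound 4 is estimated at 60000 nM with an expected range from 25000 nM to 150000 nM as a first expectation.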

Compound 4, half-maximal cytotoxic concentration: 42700 nM
The estimate for compound 4 lay 1.4-fold (0.15 log units) above the measured number; low and high end bracket the measured number.
By their numbers in this assay, from the lowest: compounds 4, 1 and 2 (each within the scatter of the next).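

In this assay, among these compounds, the swap of the 4-chlorophenyl for a 4-methoxyphenyl produces a 1.6-fold lower number from compound 2 to compound 4 (0.19 log units; within the scatter) and gives the first direct reading of a change at this position, on an aromatic carbon para to a large group. Replacing chloro with methoxy brings in a hydrogen-bond acceptor that chloro does not have, yet this single exchange leaves the two compounds indistinguishable in this measurement, so cell tolerance here shows no clear dependence on which of these two groups is present. Among the compounds shown here, as this rests on a single pair, it describes only this exchange on this core and is not a general rule for the position. No measurement at hand explains why the two numbers fall where they do.

Going by these compounds, it remains open whether a clearly different group at this position, such as an amine, a carboxylic acid or a longer chain, would shift the tolerated concentration beyond the scatter. Also open, on these data alone, is whether the same exchange of chloro for methoxy would give a similarly small step on another core or with a different group on the triazole nitrogen.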